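A few compounds are considered here, and "the series" means these few. Any claim that something is new, unique, unknown or untested is made for them only; others in the source may bear on it.

Measured compounds:
compound 1, `O=C(NCc1cccc(F)c1)c1nc([N+](=O)[O-])c(Sc2c(Cl)cncc2Cl)s1`, 1350 nM;
compound 2, `CC(=O)c1nc([N+](=O)[O-])c(Sc2c(Cl)cncc2Cl)s1`, 670 nM;
compound 3, `CCCC(=O)OC(C)c1nc([N+](=O)[O-])c(Sc2c(Cl)cncc2Cl)s1`, 4490 nM.

All three share one core and differ only in the group on the carbonyl carbon attached to it. In an assay on isolated protein for inhibition of ubiquitin carboxyl-terminal hydrolase 7 (Homo sapiens), read by fluorescence, with stated times of 30 min and 3 h (a lower number here means a stronger inhibitor, a higher number a weaker inhibitor), compound 2 holds the lowest of the three numbers. Its nearest neighbour is compound 1: the step of a 2.0-fold lower number from compound 1 to compound 2 (0.30 log units; within the scatter) lies within the scatter, so the two cannot be told apart. Compound 3 is furthest away: the step of a 6.7-fold higher number from compound 2 to compound 3 (0.83 log units; beyond the scatter) is beyond the scatter, a modest loss.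

Compound 4, `O=C(Nc1ccccc1)c1nc([N+](=O)[O-])c(Sc2c(Cl)cncc2Cl)s1`, is not yet measured. Its change from compound 2 is anilino in place of methyl on a carbonyl carbon. Going by the values given here, the step that bears most directly on it is the one from compound 1 to compound 2, where an amide built on the same carbonyl carbon gave a number within the scatter of the methyl ketone. The step from compound 2 to compound 3 shows that some changes at this carbonyl can cost a modest amount, but that change is of a different kind. On this basis compound 4 is expected to stay near compound 2, with at most a small rise, a 1.6-fold higher number from compound 2 to compound 4 (0.22 log units; within the scatter). The estimate for compound 4 in this assay is 1100 nM, within a range from 400 nM to 3200 nM.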

Compound 4, half-maximal inhibitory concentration: 40500 nM
Estimate against measurement, compound 4: 37-fold (1.57 log units) below; measured number above the stated range.
By their numbers in this assay, from the lowest: compounds 2 and 1 (each within the scatter of the next); then compound 3; then compound 4.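

In this assay, going by these compounds alone, the earlier compounds suggested that an amide on this carbonyl carbon changes little, but the step of a 30-fold higher number from compound 1 to compound 4 (1.48 log units; beyond the scatter) shows that the group on the amide-type nitrogen can matter a great deal, even with the amide itself kept. Anilino in place of methyl gives the large step of a 60-fold higher number from compound 2 to compound 4 (1.78 log units; beyond the scatter) and so costs far more than the ester-bearing change in the step of a 6.7-fold higher number from compound 2 to compound 3 (0.83 log units; beyond the scatter) did, which means that the presence of an amide does not by itself set the number at this position. No measurement given here explains why the anilino group behaves so differently from the (3-fluorobenzyl)amino group.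

Phenyl and 3-fluorobenzyl differ both in the fluorine and in the carbon that links the ring to the nitrogen, so the compounds shown cannot say which of these differences carries the loss. A plain benzyl group or a 3-fluorophenyl group on the amide nitrogen would separate the two, and a longer chain between nitrogen and ring would show how far the trend extends.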